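The source may report more compounds than this note shows. Statements on the series, on what has been measured and on what is new or still open speak of the compounds shown alone.

In a functional assay on MDA-MB-231 cells (Homo sapiens) for antiproliferative activity, read by MTT assay, with a stated time of 72 h (a lower number here means a stronger inhibitor, a higher number a weaker inhibitor), compound 2 `CSc1ccc(-c2cccc(NC(=O)CCc3cccc4c3B(O)OC4)c2)cc1` gives 140 nM and compound 1 `CSc1cccc(-c2cccc(NC(=O)CCc3cccc4c3B(O)OC4)c2)c1` gives 150 nM, so the two stand level. Compound 3 `N#Cc1cccc(-c2cccc(NC(=O)CCc3cccc4c3B(O)OC4)c2)c1` has 3-cyanophenyl in place of 4-(methylsulfanyl)phenyl on an aromatic carbon. Among the measured compounds shown here, the only measured step that bears on this is a 1.1-fold lower number from compound 1 to compound 2 (0.03 log units; within the scatter). It changes only where the methylsulfanyl group sits, so it is weak guidance for a swap to a nitrile. Nothing beyond the scatter is therefore expected in this assay. The expected change is a 1.4-fold higher number from compound 2 to compound 3 (0.15 log units; within the scatter). Compound 3 is estimated at 200 nM, with an expected range of 70 nM to 550 nM.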

Compound 3, half-maximal inhibitory concentration: 110 nM
Compound 3: middle estimate off by 1.8-fold (0.26 log units), on the high side, within the range that was stated.
By their numbers in this assay, from the lowest: compounds 3, 2 and 1 (each within the scatter of the next).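

Moving from 4-(methylsulfanyl)phenyl to 3-cyanophenyl in this assay gives a 1.3-fold lower number from compound 2 to compound 3 (0.10 log units; within the scatter), and putting cyano in place of methylsulfanyl at the same ring position gives a 1.4-fold lower number from compound 1 to compound 3 (0.13 log units; within the scatter). Both steps stay within the scatter, so this position tolerates a nitrile as well as a methylsulfanyl group, a change of group and not just a shift of the same group around the ring. No measured evidence bears on why the numbers stay level. On these data alone, whether an amine or a carboxylic acid on this ring would also hold the number level remains open.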